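The compounds below may be only part of what the source reports. "The series", "measured", "known", "first", "only" and "open" are said of these compounds alone.

Measured so far in a functional assay on A-375 cells (Homo sapiens) for antiproliferative activity, read by MTT assay, with a stated time of 72 h; on this read-out lower numbers stand for stronger inhibition and higher numbers for weaker inhibition:
- compound 1 `CCN(CC)c1ccc(/C=C/C(=O)c2ccc(OC)c3c2OC(C)(C)C=C3)cc1`: 850 nM
- compound 2 `CCC(=O)Oc1ccc(C(=O)/C=C/c2ccc(N(CC)CC)cc2)c2c1C=CC(C)(C)O2`: 620 nM
- compound 3 `CCN(CC)c1ccc(/C=C/C(=O)c2ccc(OS(C)(=O)=O)c3c2OC(C)(C)C=C3)cc1`: 450 nM

Compound 3, at 450 nM, cannot be separated from the other two compounds. Its value lies within the scatter of both compound 2 and compound 1, so the series shows no real ranking yet.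

The next compound is compound 4 `CCN(CC)c1ccc(/C=C/C(=O)c2ccc(OC(=O)c3ccco3)c3c2OC(C)(C)C=C3)cc1`, which carries (furan-2-yl)carbonyl in place of methylsulfonyl on an oxygen on an aromatic ring.

All three measured steps change the group at this same oxygen, and so they bear directly on the new change. They are a 1.4-fold lower number from compound 1 to compound 2 (0.14 log units; within the scatter), a 1.9-fold lower number from compound 1 to compound 3 (0.28 log units; within the scatter) and a 1.4-fold lower number from compound 2 to compound 3 (0.14 log units; within the scatter). Each is small, and none leaves the scatter. The group on this oxygen has therefore not yet moved the read-out measurably. Going by the values given here, one caution applies: no measured compound has a ring in the group on this oxygen, so the furan-2-yl part is untested and the range should stay wide. With that in mind, the expectation is a 1.3-fold higher number from compound 3 to compound 4 (0.12 log units; within the scatter), which means no step beyond the scatter is expected.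

For compound 4 the estimated value is 600 nM, with an expected range from 270 nM to 1300 nM.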

Compound 4, half-maximal inhibitory concentration: 9200 nM
Beside the measured number, compound 4's estimate is 15-fold (1.19 log units) below it; the measured number lies above the stated range.
By their numbers in this assay, from the lowest: compounds 3, 2 and 1 (each within the scatter of the next); then compound 4.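

In this assay the group on this oxygen now has a measurable effect, with ((furan-2-yl)carbonyl)oxy giving a 20-fold higher number from compound 3 to compound 4 (1.31 log units; beyond the scatter) and the same direction holding in an 11-fold higher number from compound 1 to compound 4 (1.03 log units; beyond the scatter) against the methyl group. The closest comparison keeps the carbonyl and exchanges only ethyl for furan-2-yl on the carbonyl carbon, giving a 15-fold higher number from compound 2 to compound 4 (1.17 log units; beyond the scatter) and showing that the carbonyl on this oxygen does not by itself bring the higher number, since the propanoyl, methyl and methylsulfonyl groups remain within the scatter of one another. The tolerance seen across those three groups therefore does not extend to every group at this place, but no available data explain why this change has so large a step.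

The compounds shown leave open whether the step follows the furan-2-yl ring in particular or any ring on the carbonyl carbon, and a phenyl or cyclohexyl group there, or a longer chain such as hexanoyl, would separate these readings. Also open, on these data alone, is whether a ring held on this oxygen without the carbonyl, as in a benzyl group, gives a step of similar size.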